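Series notes: terminal-chain variation on the shared core

The source may report more compounds than this note shows. Statements on the series, on what has been measured and on what is new or still open speak of the compounds shown alone.

Measured so far:
compound 1 `Cc1cc(OCCCO)cc(C)c1-c1cccc(COc2ccc(OCC(=O)O)c(F)c2)c1` — 110 nM
compound 2 `CC(=O)N(CC(=O)O)c1ccc(OCc2cccc(-c3c(C)cc(OCCCS(C)(=O)=O)cc3C)c2)cc1C` — "not determined" (no result reported)

Within the data shown here, in a functional assay on CHO cells for agonist activity at Free fatty acid receptor 1 (Homo sapiens), read by FLIPR and calcium flux (on this read-out lower numbers stand for an effect already at smaller amounts and higher numbers for an effect only at larger amounts of compound), compound 1 gives 110 nM; it is the only number in hand, so it stands alone and no ordering can be drawn. In this assay compound 2 gives "not determined" (no result reported), so no number is in hand for it.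

Compound 3 `COCCOc1cc(C)c(-c2cccc(COc3ccc(OCC(=O)O)c(F)c3)c2)c(C)c1` is not yet measured. It differs from compound 1 by methoxy in place of hydroxymethyl on a saturated chain carbon, two bonds along the chain from an oxygen on an aromatic ring. Among the measured compounds shown here, no comparable step between measured compounds is available, so the size of the change can only be guessed.

For compound 3 the expected step of a 1.5-fold higher number from compound 1 to compound 3 (0.16 log units; within the scatter) is small, most likely within the usual scatter, with a slight lean toward larger amounts. Compound 3 is estimated at 160 nM, within 60 nM to 450 nM.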

Compound 3, half-maximal effective concentration: 104 nM
Compound 3: the middle estimate sits 1.5-fold (0.19 log units) above what was measured; low and high end bracket the measured number.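

Methoxy in place of hydroxymethyl on a saturated chain carbon, two bonds along the chain from an oxygen on an aromatic ring, gives a 1.1-fold lower number from compound 1 to compound 3 (0.02 log units; within the scatter) in this assay on the shared core. The 3-hydroxypropoxy and 2-methoxyethoxy chains therefore read alike here, so the hydrogen-bond donor counted in hydroxymethyl is not required for a value of this size. No measured evidence bears on why the two read alike.

Going by these compounds, whether an amine, a carboxylic acid or a longer chain at this position would also read alike stays open. A single step also leaves open whether this exchange reads the same on another core.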